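Swapping One Halogen for Another: Expected Cytotoxicity

This account rests on a few compounds, and the source may have more. Where it says the series, first, only, none or still open, it means among the compounds named here.

Compound 1 `CC(=O)OC[C@H]1O[C@@H](n2c(SCc3cc4cc(F)ccc4oc3=O)nc3cncnc32)[C@H](OC(C)=O)[C@@H]1OC(C)=O`: 7600 nM
Compound 2 `CC(=O)OC[C@H]1O[C@@H](n2c(SCc3cc4cc(Br)ccc4oc3=O)nc3cncnc32)[C@H](OC(C)=O)[C@@H]1OC(C)=O`: 6700 nM
Compound 3 `CC(=O)OC[C@H]1O[C@@H](n2c(SCc3cc4cc(F)ccc4oc3=O)nc3cncnc32)[C@H](O)[C@@H]1O`: 8600 nM

All three were tested in a functional assay on Huh-5-2 cells (Homo sapiens) for cytotoxicity, read by microscopy; on this read-out higher numbers stand for lower toxicity in this test and lower numbers for higher toxicity in this test. Compound 1 and compound 2 differ in a single place: bromo in place of fluoro on an aromatic carbon. This change produced a 1.1-fold lower number from compound 1 to compound 2 (0.05 log units; within the scatter), so the two values cannot be told apart. Compound 3 shares much of its core with compound 1, but how the two cores differ is not broken down here; its value sits close to both others, all within the usual spread.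

Compound 4 `CC(=O)OC[C@H]1O[C@@H](n2c(SCc3cc4cc(Br)ccc4oc3=O)nc3cncnc32)[C@H](O)[C@@H]1O` has not yet been measured. It differs from compound 3 by the same change: bromo in place of fluoro on an aromatic carbon. Because that change gave a 1.1-fold lower number from compound 1 to compound 2 (0.05 log units; within the scatter), the step of a 1.1-fold lower number from compound 3 to compound 4 (0.04 log units; within the scatter) is expected to be just as small. Compound 4 is therefore estimated at about 7800 nM, with a likely range from 4000 nM to 16000 nM.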

Compound 4, half-maximal cytotoxic concentration: 31000 nM
Beside the measured number, compound 4's estimate is 4.0-fold (0.60 log units) below it, outside the stated range (above it).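

Bromo in place of fluoro gave a 3.6-fold higher number from compound 3 to compound 4 (0.56 log units; beyond the scatter) in this assay, so on this core the swap goes with lower toxicity in this test. Set beside the earlier step, the same swap does not carry over unchanged from one core to the other: the same change on two cores in this assay, a 1.1-fold lower number (0.05 log units; within the scatter) from compound 1 to compound 2 and a 3.6-fold higher number (0.56 log units; beyond the scatter) from compound 3 to compound 4, 4.1-fold (0.61 log units) apart, beyond the scatter of two such steps

Going by these compounds alone, this rests on only two pairs, so it shows that the outcome of the swap depends on the core here, but not which difference between the cores is responsible or what the swap would do on any further core. The compounds shown carry only fluoro or bromo at this aromatic carbon. On these data alone, whether chloro or an amine there would track the small step or the larger one on these two cores remains open.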